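Acyl chain variation: saturating the ester side chain

This account rests on a few compounds, and the source may have more. Where it says the series, first, only, none or still open, it means among the compounds named here.

Measured so far in an assay on HeLa cells for inhibition of DNA topoisomerase 1 (Homo sapiens); a lower number here means a stronger inhibitor, a higher number a weaker inhibitor:
- compound 1 `CC(C)=CC[C@@H](OC(=O)C(C)C)C1=CC(=O)c2c(O)ccc(O)c2C1=O` gives 84000 nM
- compound 2 `CCC/C=C/C(=O)O[C@H](CC=C(C)C)C1=CC(=O)c2c(O)ccc(O)c2C1=O` gives 153000 nM
- compound 3 `CC/C=C/CC(=O)O[C@H](CC=C(C)C)C1=CC(=O)c2c(O)ccc(O)c2C1=O` gives 153000 nM

Compound 3 stands level with compound 2 at the digits shown, the two together the highest numbers of the three; its nearest neighbour is compound 2, no change at the digits printed from compound 2 to compound 3 (within the scatter), its furthest compound 1, a 1.8-fold higher number from compound 1 to compound 3 (0.26 log units; within the scatter). Compound 4 `CCCCCCC(=O)O[C@H](CC=C(C)C)C1=CC(=O)c2c(O)ccc(O)c2C1=O` differs from compound 3 in one place: pentyl in place of but-1-en-1-yl on a saturated chain carbon bound to a carbonyl carbon. Among the measured compounds shown here, every step so far that touched the acyl group stayed inside the scatter: a 1.8-fold higher number from compound 1 to compound 2 (0.26 log units; within the scatter), a 1.8-fold higher number from compound 1 to compound 3 (0.26 log units; within the scatter) and no change at the digits printed from compound 2 to compound 3 (within the scatter). A further swap within the same chain is therefore expected to give no step beyond the scatter in this assay, a 1.0-fold lower number from compound 3 to compound 4 (0.01 log units; within the scatter). Compound 4 is estimated at 150000 nM, expected range 70000 nM to 320000 nM.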

Compound 4, half-maximal inhibitory concentration: 625000 nM
Beside the measured number, compound 4's estimate is 4.2-fold (0.62 log units) below it; measured number above the stated range.
By their numbers in this assay, from the lowest: compounds 1, 2 and 3 (each within the scatter of the next); then compound 4.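

In this assay, among the compounds shown here, the acyl chain is no longer silent: pentyl in place of but-1-en-1-yl gives a 4.1-fold higher number from compound 3 to compound 4 (0.61 log units; beyond the scatter) and is the first step here beyond the scatter. Hexyl on the carbonyl carbon also gives a 4.1-fold higher number from compound 2 to compound 4 (0.61 log units; beyond the scatter) against pent-1-en-1-yl and a 7.4-fold higher number from compound 1 to compound 4 (0.87 log units; beyond the scatter) against isopropyl, which leaves compound 4 the weakest of the four. Nothing measured accounts for this loss.

The step removes a double bond and adds a carbon together, so the two changes remain unseparated. A shorter saturated chain such as butyl, or a longer one such as octyl, would test chain length on its own.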